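The compounds below may be only part of what the source reports. "The series", "measured", "known", "first", "only" and "open" are said of these compounds alone.

Compound 1, `COc1ccc(OC)c(S(=O)(=O)Nc2cncc(-c3ccncc3)c2)c1`: 73 nM
Compound 2, `COc1ccc(Cl)cc1S(=O)(=O)Nc1cncc(-c2ccncc2)c1`: 73 nM
Compound 3, `COc1ccc(C(F)(F)F)cc1S(=O)(=O)Nc1cccnc1`: 183 nM

All three compounds were tested in an assay on isolated protein for inhibition of alkaline phosphatase, tissue-nonspecific isozyme (Homo sapiens); on this read-out higher numbers stand for weaker inhibition and lower numbers for stronger inhibition. Compound 2 stands level with compound 1, and together they give the lowest numbers of the three; compound 3 gives a higher number than compound 2, and that gap lies beyond the usual scatter. Between compound 1 and compound 2 the single change is no change at the digits printed from compound 1 to compound 2 (within the scatter), so swapping those two groups on the shared core made no difference.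

Compound 4, `COc1ccc(Cl)cc1S(=O)(=O)Nc1cncc(-c2ccc(C)cc2)c1`, differs from compound 2 in one place: 4-methylphenyl in place of pyridin-4-yl on an aromatic carbon. Among the measured compounds shown here, no measured step bears directly on this change, because the only one-place step on record, no change at the digits printed from compound 1 to compound 2 (within the scatter), concerns the other side of the molecule. Compound 3, which carries no aryl group at that place and also a different substituent elsewhere, gives a higher number than compound 2, but it differs in more than one place, so it says little about this particular swap. The expectation is therefore cautious: a modest move toward a higher number in this assay, a 1.8-fold higher number from compound 2 to compound 4 (0.25 log units; within the scatter), is estimated for compound 4. Compound 4 is expected to give about 130 nM, within a range from 45 nM to 400 nM.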

Compound 4, half-maximal inhibitory concentration: 147 nM
The estimate for compound 4 lay 1.1-fold (0.05 log units) below the measured number; the range from low to high includes it.
By their numbers in this assay, from the lowest: compounds 1, 2, 4 and 3 (each within the scatter of the next, the first and the last beyond it).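

Replacing pyridin-4-yl with 4-methylphenyl on this aromatic carbon gives, in this assay, a 2.0-fold higher number from compound 2 to compound 4 (0.30 log units; within the scatter), so this swap cannot be told apart from the ordinary spread of repeated measurements. Among the compounds shown here, the only earlier one-place step concerned the other side of the molecule, whereas this one shows that, for this pair, the ring nitrogen and the hydrogen-bond acceptor counted with it can be lost while the result stays within the scatter of compound 2. Nothing measured here explains that outcome.

The swap removes the ring nitrogen and adds a methyl group at once, so the compounds shown cannot separate these two changes; a plain phenyl group at this place would be needed to divide them. Going by these compounds, it also remains open how far this tolerance extends, since these compounds do not show how the number would respond to an amine, a carboxylic acid or a saturated ring such as morpholine at the same place.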